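Trimethoxyphenyl triazolothiadiazine series: aryl ketone variation

The source may report more compounds than this note shows. Statements on the series, on what has been measured and on what is new or still open speak of the compounds shown alone.

Compound 1, `COc1cc(-c2nnc3n2NC(c2ccco2)C(C(=O)c2ccc(Br)cc2)S3)cc(OC)c1OC`, gives > 100000 nM in a functional assay on MCF7 cells (Homo sapiens) for cytotoxicity, read by MTT assay, with a stated time of 48 h; a higher number here means a weaker inhibitor, a lower number a stronger inhibitor; this is a limit of the assay, not a number.
Compound 2, `COc1cc(-c2nnc3n2NC(c2ccco2)C(C(=O)c2ccc(Cl)cc2)S3)cc(OC)c1OC`, gives > 100000 nM in this assay; again a limit.
Compound 3, `COc1cc(-c2nnc3n2NC(c2ccco2)C(C(=O)c2ccc(O)cc2)S3)cc(OC)c1OC`, gives 88900 nM in this assay.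

Among the compounds with values here, compound 3 holds the only number measured so far; the other two values sit at the limit (the limit of > 100000 nM in this assay, at which 2 of the 3 values shown sit). The steps of an at least 1.1-fold lower number from compound 1 to compound 3 (0.05 log units; that floor lies within the scatter) and an at least 1.1-fold lower number from compound 2 to compound 3 (0.05 log units; that floor lies within the scatter) are readable only as floors, and both lie within the scatter. The step that the two limits leave unreadable from compound 1 to compound 2 cannot be read.

Compound 4, `COc1cccc(C(=O)C2Sc3nnc(-c4cc(OC)c(OC)c(OC)c4)n3NC2c2ccco2)c1`, differs from compound 3 by 3-methoxyphenyl in place of 4-hydroxyphenyl on a carbonyl carbon. Within the data shown here, no measured step replaces hydroxy with methoxy, so the three weak values are the only guide. Compound 4 is expected to remain near the limit, with a step of a 1.1-fold higher number from compound 3 to compound 4 (0.05 log units; within the scatter) estimated as within the scatter. The estimate for compound 4 is 100000 nM, between 40000 nM and 250000 nM.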

Compound 4, half-maximal inhibitory concentration: > 100000 nM
Compound 4: only a limit was reported (the forecaster's own chance of this, stated with the estimate: 55%); the middle value lies on the limit itself.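

In this assay, the change on the carbonyl carbon gives an at least 1.1-fold higher number from compound 3 to compound 4 (0.05 log units; that floor lies within the scatter), so the size of any loss cannot be read. The steps from compound 1 and compound 2 to compound 4 cannot be read either, since both ends are limits. With 3-methoxyphenyl, which has no hydrogen-bond donor, compound 4 also gives only a limit, so compound 3 still holds the only number: the limit of > 100000 nM in this assay, at which 3 of the 4 values shown sit.

From the compounds shown here alone, whether the hydroxy group or its place on the ring matters remains open, since the step changes both. An amine or a carboxylic acid on this aryl ring could show whether this position can give values clear of the limit.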